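The source may report more compounds than this note shows. Statements on the series, on what has been measured and on what is new or still open speak of the compounds shown alone.

Measured so far:
compound 1 `O=Cc1c(-c2ccc(Cl)cc2Cl)nc2sc(Cc3ccc(Cl)cc3)nn12` gives 64000 nM
compound 2 `O=Cc1c(-c2ccccc2)nc2sc(Cc3ccc(Cl)cc3)nn12` gives 45000 nM
compound 3 `N#CSc1c(-c2ccc(Cl)cc2Cl)nc2sc(Cc3ccc(Cl)cc3)nn12` gives 18000 nM

These three compounds were tested in a functional assay on HeLa cells (Homo sapiens) for cytotoxicity, with a stated time of 72 h; a lower number here means a stronger inhibitor, a higher number a weaker inhibitor. Compound 3 is set apart from compound 1 by cyanosulfanyl in place of formyl on an aromatic carbon, and that change brought a 3.6-fold lower number from compound 1 to compound 3 (0.55 log units; beyond the scatter). Compound 1 and compound 2 share the core of compound 3 only in part; their cores differ as just described, and between them the change is phenyl in place of 2,4-dichlorophenyl on an aromatic carbon, which brought a 1.4-fold lower number from compound 1 to compound 2 (0.15 log units; within the scatter).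

Compound 4 `N#CSc1c(-c2ccccc2)nc2sc(Cc3ccc(Cl)cc3)nn12` has not yet been tested. It differs from compound 3 by phenyl in place of 2,4-dichlorophenyl on an aromatic carbon. This is the same kind of change as from compound 1 to compound 2, though the surroundings are not identical: in compound 3 the place lies next to the ring atom that bears a cyanosulfanyl group (3 heavy atoms), whereas in compound 1 it lies next to the ring atom that bears a formyl group (2 heavy atoms). Since the earlier change of this kind gave a 1.4-fold lower number from compound 1 to compound 2 (0.15 log units; within the scatter), a step of about a 1.4-fold lower number from compound 3 to compound 4 (0.14 log units; within the scatter) is expected here. Compound 4 is therefore estimated at 13000 nM, likely between 5000 nM and 35000 nM.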

Compound 4, half-maximal inhibitory concentration: 12000 nM
The estimate for compound 4 lay 1.1-fold (0.03 log units) above the measured number; the measured number falls inside the stated range.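

In this assay, phenyl in place of 2,4-dichlorophenyl gives a 1.5-fold lower number from compound 3 to compound 4 (0.18 log units; within the scatter), and this matches the same change made on the core of compound 1: the same change on two cores in this assay, a 1.4-fold lower number (0.15 log units; within the scatter) from compound 1 to compound 2 and a 1.5-fold lower number (0.18 log units; within the scatter) from compound 3 to compound 4, 1.1-fold (0.02 log units) apart, within the scatter of two such steps

Cyanosulfanyl in place of formyl gives a 3.8-fold lower number from compound 2 to compound 4 (0.57 log units; beyond the scatter), and this too carries over from the 2,4-dichlorophenyl compounds to the phenyl compounds: the same change on two cores in this assay, a 3.6-fold lower number (0.55 log units; beyond the scatter) from compound 1 to compound 3 and a 3.8-fold lower number (0.57 log units; beyond the scatter) from compound 2 to compound 4, 1.1-fold (0.02 log units) apart, within the scatter of two such steps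

For the compounds shown here, this shows that both changes transferred between these cores, although the phenyl step lies within the scatter, so its agreement shows only that neither core reveals a clear effect of that change, and two pairs cannot show that either change would transfer to other cores.

As far as these compounds go, it remains open whether other groups would behave the same way, such as an amine or a carboxylic acid in place of cyanosulfanyl. A longer chain in place of phenyl is equally untested in the compounds shown.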